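A few compounds are considered here, and "the series" means these few. Any claim that something is new, unique, unknown or untested is made for them only; others in the source may bear on it.

Measured so far: compound 1, `ClCc1cccc(Cn2cnc3c(Cl)ncnc32)c1`, gives 31600 nM in a functional assay on HOP-92 cells (Homo sapiens) for cytotoxicity, read by sulforhodamine B assay, with a stated time of 48 h; a higher number here means that more compound is tolerated, a lower number that less compound is tolerated; compound 2, `ClCc1cccc(Cn2cnc3c(Cl)nc(Cl)nc32)c1`, gives 7080 nM in this assay; compound 3, `ClCc1ccccc1Cn1cnc2ncnc(Cl)c21`, gives 51300 nM in this assay.

Compound 1 and compound 2 differ in one place, (chloro in place of hydrogen on an aromatic carbon), and that change made a 4.5-fold lower number from compound 1 to compound 2 (0.65 log units; beyond the scatter). Compound 3 has the same atoms as compound 1 joined differently; the difference between the two cores is not broken down here, and their two values lie within the scatter of each other.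

Compound 4, `ClCc1ccccc1Cn1cnc2nc(Cl)nc(Cl)c21`, is not yet measured. It stands to compound 3 as compound 2 stands to compound 1: chloro in place of hydrogen on an aromatic carbon, the same change at the same place. Resting on the step from compound 1 to compound 2, compound 4 is expected to show a 4.5-fold lower number from compound 3 to compound 4 (0.65 log units; beyond the scatter) in this assay. The estimate for compound 4 is therefore 11400 nM, between 5000 nM and 26000 nM.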

Compound 4, concentration lethal to 50% of the cells: > 100000 nM
Compound 4: a limit, no number (the forecaster's own chance of this, stated with the estimate: 0%); middle value at least 8.7-fold (0.94 log units) away from the limit.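

On the core of compound 3, chloro in place of hydrogen on an aromatic carbon gave an at least 1.9-fold higher number from compound 3 to compound 4 (0.28 log units; that floor lies within the scatter). The same change therefore did not carry over from one core to the other in this assay: the same change on two cores in this assay, a 4.5-fold lower number (0.65 log units; beyond the scatter) from compound 1 to compound 2 and an at least 1.9-fold higher number (0.28 log units; that floor lies within the scatter) from compound 3 to compound 4, at least 8.7-fold (0.93 log units) apart, beyond the scatter of two such steps. For compound 4, > 100000 nM is a limit of the assay and not a number, so the true size of this step is not known: the limit of > 100000 nM in this assay, at which 1 of the 4 values shown sits.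

Why the two cores part ways stays open. On these data alone, it is also open whether a different group on that aromatic carbon, such as an amine, would split between the two cores in the same way.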